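This account rests on a few compounds, and the source may have more. Where it says the series, first, only, none or still open, it means among the compounds named here.

Measured in an ADME assay on PC-3 cells (Homo sapiens) for cytotoxicity, read by sulforhodamine B assay, with a stated time of 48 h, tested at 10 uM; a lower number here means less inhibition, a higher number more inhibition at the concentration tested (going by the name of the read-out):
- compound 1 `COc1nc2ccc(Br)cc2cc1C(c1ccccc1)n1cc(-c2ccc(Br)cc2)nn1` gives 7.43%
- compound 2 `CCOC(=O)c1cn(C(c2ccccc2)c2cc3cc(Br)ccc3nc2OC)nn1` gives 16.1%
- compound 3 `COc1nc2ccc(Br)cc2cc1C(c1ccccc1)n1cc(CCCO)nn1` gives 14.7%

Compound 3 holds the second highest of the three numbers in this assay. Its nearest neighbour is compound 2, with a number 1.4 percentage points lower from compound 2 to compound 3 (within the scatter); its furthest is compound 1, with a number 7.3 percentage points higher from compound 1 to compound 3 (within the scatter). Both gaps sit within the scatter, as does a number 8.7 percentage points higher from compound 1 to compound 2 (within the scatter), so the three measured compounds cannot be told apart on these numbers.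

Compound 4 `COc1nc2ccc(Br)cc2cc1C(c1ccccc1)n1cc(CCCCCO)nn1` is the next member. The change from compound 3 is 2-hydroxyethyl in place of hydroxy on a saturated chain carbon, three bonds along the chain from an aromatic carbon.

Among the measured compounds shown here, none of the measured steps touches this position: each of them exchanges the whole group on the aromatic carbon of the shared core, and none of them alters the chain length of the 3-hydroxypropyl group. The three measured steps are therefore only indirect guides, and all three stayed within the scatter. Nothing in the series points to a step beyond the scatter for compound 4 in this assay, in either direction.

The step from compound 3 to compound 4 is expected to be small, a number 0.7 percentage points lower from compound 3 to compound 4 (within the scatter). Compound 4 is estimated at 14%, with a range from 4% to 26%.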

Compound 4, a percentage reported as inhibition, at one concentration (the size of the read-out at that concentration, not a potency): 12.9%
For compound 4 the middle estimate is 1.1 percentage points above the measured one; the measured number falls inside the stated range.
By their numbers in this assay, from the lowest: compounds 1, 4, 3 and 2 (each within the scatter of the next).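

In this assay the chain itself now has a reading, with a number 1.8 percentage points lower from compound 3 to compound 4 (within the scatter) for 2-hydroxyethyl in place of hydroxy on a saturated chain carbon, three bonds along the chain from an aromatic carbon, so going from 3-hydroxypropyl to 5-hydroxypentyl gives no step beyond the scatter at this position. Exchanging the whole group also stays within the scatter with 5-hydroxypentyl as the partner, with a number 3.2 percentage points lower from compound 2 to compound 4 (within the scatter) against ethoxycarbonyl and a number 5.5 percentage points higher from compound 1 to compound 4 (within the scatter) against 4-bromophenyl, so compound 4 cannot be told apart from compound 1, compound 2 or compound 3. No measurement at hand offers an explanation for the size of these steps.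

Still open, from the compounds shown here alone, is whether a shorter hydroxymethyl chain, a chain longer than 5-hydroxypentyl, or an amine or a carboxylic acid at the chain end in place of the hydroxy group would give a step beyond the scatter. Going by these compounds, each number is also a reading at a single concentration and not a potency, so how these compounds compare at other concentrations remains unknown.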